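Two Urea Amines, Two Benzyl Groups, One Cytotoxicity Read-out

A few compounds are considered here, and "the series" means these few. Any claim that something is new, unique, unknown or untested is made for them only; others in the source may bear on it.

Compound 1 `CC(C)NC(=O)N1CCN(C(=S)SCc2cn(Cc3ccc(F)cc3)nn2)CC1`: 5970 nM
Compound 2 `CCN(C)C(=O)N1CCN(C(=S)SCc2cn(Cc3ccc(F)cc3)nn2)CC1`: 23700 nM
Compound 3 `Cc1ccc(Cn2cc(CSC(=S)N3CCN(C(=O)NC(C)C)CC3)nn2)cc1`: > 128000 nM, a limit of the assay rather than a number

In a functional assay on SMMC-7721 cells (Homo sapiens) for cytotoxicity, read by MTT assay, with a stated time of 72 h (on this read-out higher numbers stand for weaker inhibition and lower numbers for stronger inhibition), the change ethyl(methyl)amino in place of isopropylamino on a carbonyl carbon produced a 4.0-fold higher number from compound 1 to compound 2 (0.60 log units; beyond the scatter). The cores of compound 1 and compound 3 differ by methyl in place of fluoro on an aromatic carbon, and that difference gave an at least 21-fold higher number from compound 1 to compound 3 (1.33 log units; beyond the scatter). Compound 3 therefore stands at the limit of > 128000 nM in this assay, at which 1 of the 3 values shown sits.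

Compound 4 `CCN(C)C(=O)N1CCN(C(=S)SCc2cn(Cc3ccc(C)cc3)nn2)CC1` carries the change (ethyl(methyl)amino in place of isopropylamino on a carbonyl carbon), the same change at the same place as between compound 1 and compound 2. From compound 3 to compound 4 a step that the limit leaves unreadable from compound 3 to compound 4 is expected, resting on the step that compound 1 showed in a 4.0-fold higher number from compound 1 to compound 2 (0.60 log units; beyond the scatter). Compound 4 is estimated at 400000 nM, between 128000 nM and 1500000 nM, and this assay will most likely again report only a limit.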

Compound 4, half-maximal inhibitory concentration: > 128000 nM
Compound 4: a limit, no number; the forecaster's own chance of this, stated with the estimate: 85%; the middle value is on the limit's open side.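

In this assay compound 4 gives > 128000 nM, which is a limit and not a number, so the step from isopropylamino to ethyl(methyl)amino cannot be read on the core that carries methyl. Methyl in place of fluoro on an aromatic carbon gave an at least 5.4-fold higher number from compound 2 to compound 4 (0.73 log units; beyond the scatter). This change moves the number the same way with both urea amines, but the sizes of the two steps cannot be compared: the same change on two cores in this assay, an at least 21-fold higher number (1.33 log units; beyond the scatter) from compound 1 to compound 3 and an at least 5.4-fold higher number (0.73 log units; beyond the scatter) from compound 2 to compound 4; the limit leaves it open whether they differ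

The compounds shown leave open how chloro or methoxy in place of fluoro would read. They also leave open whether a cyclic amine such as pyrrolidine on the carbonyl carbon would give a number rather than a limit on the methyl core.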